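Swapping an N-Aryl Group for an Acetylcyclohexylmethyl Chain

This account rests on a few compounds, and the source may have more. Where it says the series, first, only, none or still open, it means among the compounds named here.

Compound 1 `CC(C)c1onc(-c2c(Cl)cccc2Cl)c1COc1ccc(-c2nc3ccc(C(=O)O)cc3n2-c2ccc(F)cc2)cc1` gives 32.2 nM in an assay on Huh-7 cells for agonist activity at Bile acid receptor (Homo sapiens), read by a luciferase reporter (on this read-out lower numbers stand for an effect already at smaller amounts and higher numbers for an effect only at larger amounts of compound), the highest of the three numbers measured. Compound 2 `CC(C)c1onc(-c2c(Cl)cccc2Cl)c1COc1ccc(-c2nc3ccc(C(=O)O)cc3n2C)c(Cl)c1` gives 3.66 nM, and compound 3 `CCC(CC)n1c(-c2ccc(OCc3c(-c4c(Cl)cccc4Cl)noc3C(C)C)cc2Cl)nc2ccc(C(=O)O)cc21` gives 1.6 nM. Compound 4 `CC(=O)C1CCC(Cn2c(-c3ccc(OCc4c(-c5c(Cl)cccc5Cl)noc4C(C)C)cc3)nc3ccc(C(=O)O)cc32)CC1` arises from compound 1 by (4-acetylcyclohexyl)methyl in place of 4-fluorophenyl on an aromatic nitrogen. Among the measured compounds shown here, the only measured step at this same position is a 2.3-fold lower number from compound 2 to compound 3 (0.36 log units; beyond the scatter), where a bulkier saturated group replaced a small one and the number fell modestly. For the measured compounds named here, compound 1, however, carries an aryl group at that position and also differs from compounds 2 and 3 elsewhere, so no single-point step connects it to them. A lower number is nonetheless expected for compound 4, with a 3.2-fold lower number from compound 1 to compound 4 (0.51 log units; beyond the scatter) uncertain in size. Compound 4 is therefore estimated at 10 nM, in a range from 3 nM to 35 nM.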

Compound 4, half-maximal effective concentration: 1170 nM
Compound 4: the middle estimate sits 120-fold (2.07 log units) below what was measured, outside the stated range (above it).
By their numbers in this assay, from the lowest: compound 3; then compound 2; then compound 1; then compound 4.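

In this assay, the position on the aromatic nitrogen does not accept every large group: (4-acetylcyclohexyl)methyl in place of 4-fluorophenyl gives a 36-fold higher number from compound 1 to compound 4 (1.56 log units; beyond the scatter), a large change. The step from compound 2 to compound 3 had gone the other way, so a non-aromatic group here does not by itself bring a lower number. No supporting measurement bears on why the number rose. Still open, on these data alone, is whether the change follows the acetyl group or the cyclohexylmethyl part, which a plain cyclohexylmethyl group or a carboxylic acid in place of the acetyl could separate.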